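Diaryl urea series: trifluoromethyl to chloro on the terminal ring

A few compounds are considered here, and "the series" means these few. Any claim that something is new, unique, unknown or untested is made for them only; others in the source may bear on it.

The compounds share a quinoline-ether urea core. Compound 1 `COc1cc2cc(Oc3ccc(NC(=O)Nc4cccc(C(F)(F)F)c4)cc3)c(C)nc2cc1OC` is the parent; in a functional assay on SW-620 cells (Homo sapiens) for inhibition, read by sulforhodamine B assay, with a stated time of 48 h (on this read-out higher numbers stand for weaker inhibition of growth and lower numbers for stronger inhibition of growth), compound 1 gives 11100 nM. For the measured compounds named here, compound 2 `COc1cc2cc(Oc3ccc(NC(=O)Nc4ccc(Cl)c(C(F)(F)F)c4)cc3)c(C)nc2cc1OC` carries an added chloro, and in this assay compound 2 gives 4570 nM, the lowest of the two numbers so far. The step from the parent, a 2.4-fold lower number from compound 1 to compound 2 (0.39 log units; beyond the scatter), is modest but beyond the scatter.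

Compound 3 `COc1cc2cc(Oc3ccc(NC(=O)Nc4ccc(Cl)c(Cl)c4)cc3)c(C)nc2cc1OC` differs from compound 2 by chloro in place of trifluoromethyl on an aromatic carbon, which reads as 4-chloro-3-(trifluoromethyl)phenyl to 3,4-dichlorophenyl. Going by the values given here, no measured step covers this particular exchange; the only step available, a 2.4-fold lower number from compound 1 to compound 2 (0.39 log units; beyond the scatter), concerns the neighbouring chloro and says nothing direct about replacing trifluoromethyl. With only that to go on, the expectation for compound 3 in this assay is a step of a 1.3-fold higher number from compound 2 to compound 3 (0.12 log units; within the scatter) that stays within or close to the scatter, with a wide range either way. The estimate for compound 3 is 6000 nM, with a range from 2500 nM to 15000 nM.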

Compound 3, concentration for total growth inhibition: 15600 nM
Compound 3: middle estimate off by 2.6-fold (0.41 log units), on the low side; the whole stated range lies below it.
By their numbers in this assay, from the lowest: compound 2; then compounds 1 and 3 (each within the scatter of the next).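

In this assay, chloro does not stand in for trifluoromethyl at this position when the neighbouring chloro is kept (a 3.4-fold higher number from compound 2 to compound 3 (0.53 log units; beyond the scatter)), a modest step beyond the scatter. The terminal-ring change from compound 1 to compound 3 stays within the scatter (a 1.4-fold higher number from compound 1 to compound 3 (0.15 log units; within the scatter)), so the lower number of compound 2 belongs to the 4-chloro-3-(trifluoromethyl)phenyl pairing and does not appear with 3,4-dichlorophenyl, at least among these three compounds. No supporting data bear on what separates the two groups here.

Open, as far as these compounds go, is whether a different group on this aromatic carbon, such as bromo, methyl, methoxy or nitrile, would read like trifluoromethyl in compound 2 or like chloro in compound 3, and so whether trifluoromethyl is unusual here or chloro is. For the compounds shown here, also open is whether an amine or a carboxylic acid on the terminal ring would shift the number further, and whether the same exchange gives a step of similar size on a core other than the one shared by these compounds.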